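A few compounds are considered here, and "the series" means these few. Any claim that something is new, unique, unknown or untested is made for them only; others in the source may bear on it.

In an ADME assay on the whole organism (Mus musculus, strain CD1) for pharmacokinetics, at a dose of 10 mg/kg by the oral route (a lower number here means that a smaller share of the oral dose reaches the circulation, a higher number that a larger share of the oral dose reaches the circulation), compound 2 `Cc1cc(N2C(=O)C3(CCC3)N(c3ccc(OC4CCNCC4)nc3)C2=S)cnc1C#N` gives 92%, the highest of the three numbers in hand. Compound 1 `CN1CCC(Oc2ccc(N3C(=S)N(c4cnc(C#N)c(C(F)(F)F)c4)C(=O)C34CCC4)cn2)CC1` gives 56% and compound 3 `N#Cc1ncc(N2C(=O)C3(CCC3)N(c3ccc(OC4CCNCC4)cc3)C2=S)cc1Cl` gives 50%. Both lie beyond the scatter under compound 2 and within the scatter of each other.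

Compound 4 `N#Cc1ncc(N2C(=O)C3(CCC3)N(c3ccc(OC4CCNCC4)nc3)C2=S)cc1C(F)(F)F` has not yet been measured. It differs from compound 2 in one place, with trifluoromethyl in place of methyl on an aromatic carbon, ortho to a cyano group (trifluoromethyl in place of methyl on an aromatic carbon). Among the compounds with values here, no measured pair shows this change on its own, so its size cannot be read directly from the series. Within the data shown here, the only guide is the spread of values: the number for compound 2 stands alone at the top, while the other two measured compounds sit together well under it. A fall is therefore expected rather than a rise, and one likely to lie beyond the scatter. The expected change is a number 30 percentage points lower from compound 2 to compound 4 (beyond the scatter). For compound 4 the estimated value is 62%, with an expected range of 40% to 82%.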

Compound 4, oral bioavailability: 45%
The estimate for compound 4 lay 17 percentage points above the measured number; measured number inside the range.
By their numbers in this assay, from the lowest: compounds 4, 3 and 1 (each within the scatter of the next, the first and the last beyond it); then compound 2.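

In this assay, within the data shown here, the first direct reading at this position is a number 47 percentage points lower from compound 2 to compound 4 (beyond the scatter), a large step for trifluoromethyl in place of methyl on an aromatic carbon ortho to a cyano group, so the top number does not survive this single change. With trifluoromethyl held in place, hydrogen in place of methyl on an amine nitrogen in a ring gives a number 11 percentage points lower from compound 1 to compound 4 (beyond the scatter), a modest step beyond the scatter, so this change at the ring amine weighs much less here than the change on the aromatic carbon. Nothing in hand gives a cause for either step.

From the compounds shown here alone, whether a smaller group such as fluorine or a larger one such as ethyl at this position would stay near the methyl compound remains open. Also open, going by these compounds, is how a longer chain on the amine nitrogen would read with methyl on the aromatic carbon.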